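The compounds below may be only part of what the source reports. "The series", "measured", "known", "first", "only" and "open" are said of these compounds alone.

Compound 2 `O=CCN1N=C(c2ccc3ccccc3c2)CC1c1cccc([N+](=O)[O-])c1` holds the lowest of the two numbers recorded so far: in a functional assay on OVCAR cells (Homo sapiens) for cytotoxicity, read by sulforhodamine B assay, with a stated time of 48 h (on this read-out lower numbers stand for stronger inhibition and higher numbers for weaker inhibition), compound 2 gives 3390 nM. Its nearest neighbour is compound 1 `COc1ccc(OC)c(C2CC(c3ccco3)=NN2C(C)=O)c1`, which in this assay gives 11000 nM, a gap beyond the scatter. Compound 3 `O=CCN1N=C(c2ccc3ccccc3c2)CC1c1cccc(Cl)c1Cl` differs from compound 2 in a single place: 2,3-dichlorophenyl in place of 3-nitrophenyl on a saturated ring carbon. For the measured compounds named here, no step between measured compounds that differ in one place is known, so nothing calibrates this change. The step of a 1.1-fold lower number from compound 2 to compound 3 (0.05 log units; within the scatter) is expected to stay within the scatter, in no clear direction. The estimate for compound 3 is 3000 nM, with a range from 1000 nM to 10000 nM.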

Compound 3, half-maximal inhibitory concentration: 15100 nM
For compound 3 the middle estimate is 5.0-fold (0.70 log units) below the measured one; the measured number lies above the stated range.
By their numbers in this assay, from the lowest: compound 2; then compounds 1 and 3 (each within the scatter of the next).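

In this assay, this is the first one-place change among the compounds shown, and it shows that the group on this saturated ring carbon matters: 2,3-dichlorophenyl in place of 3-nitrophenyl gives a 4.5-fold higher number from compound 2 to compound 3 (0.65 log units; beyond the scatter). Within this pair, the 3-nitrophenyl compound therefore holds the lower number. Nothing available explains this step.

A single step cannot separate the loss of the nitro group from the arrival of the two chlorine atoms. Going by these compounds, it also remains open whether a plain phenyl or a 3-aminophenyl here would sit nearer compound 2 or compound 3.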